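A few compounds are considered here, and "the series" means these few. Any claim that something is new, unique, unknown or untested is made for them only; others in the source may bear on it.

Compound 3 `CN(C)c1ncc(C#Cc2c(F)cccc2F)c2ccccc12` and compound 2 `Fc1cccc(F)c1C#Cc1cncc2ccccc12` share a core and differ by hydrogen in place of dimethylamino on an aromatic carbon. In a functional assay on LS174T cells (Homo sapiens) for inhibition, with a stated time of 4 days, tested at 10 uM (a lower number here means a weaker effect, a higher number a stronger effect of the compound at the concentration tested), compound 3 gives 97.6%, and compound 2 gives 87.9%, so the step is a number 9.7 percentage points lower from compound 3 to compound 2 (within the scatter). Compound 1 `CN(C)c1ccc2cc(C#Cc3c(F)cccc3F)ccc2n1` is built on a different core, and the difference between the two cores is not broken down here; in this assay compound 1 gives 38.7%, the lowest of the three numbers, and the gaps to compound 2 and compound 3 are both beyond the scatter. Compound 4 `Fc1cccc(F)c1C#Cc1ccc2ncccc2c1` is not yet measured and differs from compound 1 by hydrogen in place of dimethylamino on an aromatic carbon, the same kind of change as that from compound 3 to compound 2, though here the carbon is meta and para to a fused ring rather than ortho to a fused ring and para to a large group. Since the step of a number 9.7 percentage points lower from compound 3 to compound 2 (within the scatter) stayed within the scatter, a step of similar size is expected from compound 1 to compound 4, namely a number 4.7 percentage points lower from compound 1 to compound 4 (within the scatter). Compound 4 is therefore estimated at 34% in this assay, between 14% and 58%.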

Compound 4, a percentage reported as inhibition, at one concentration (the size of the read-out at that concentration, not a potency): 80.1%
Beside the measured number, compound 4's estimate is 46.1 percentage points below it; measured number outside the range, above it.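

In this assay, the exchange of dimethylamino for hydrogen on an aromatic carbon gives a number 41.4 percentage points higher from compound 1 to compound 4 (beyond the scatter). The change therefore does not carry over unchanged between these two cores: the same change on two cores in this assay, a number 9.7 percentage points lower (within the scatter) from compound 3 to compound 2 and a number 41.4 percentage points higher (beyond the scatter) from compound 1 to compound 4, 51.1 percentage points apart, beyond the scatter of two such steps This shows that, in this series, the step measured on one core did not predict the step on the other, but with one pair on each core and a single concentration, it does not show why they differ or how the change would behave on any further core.

The compounds shown leave open how a methylamino group, a morpholine or a methoxy group would read in place of dimethylamino on either core.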